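A Thiazolyl Amide Variant of Compound 1

The source may hold more compounds than are shown below. What is called first, only, known or untested is meant among the compounds shown, and "the series" means these compounds.

Three amides sharing one core have been measured in a functional assay on MDA-MB-231 cells (Homo sapiens) for cytotoxicity, read by MTT assay; a higher number here means a weaker inhibitor, a lower number a stronger inhibitor. Compound 1 `CCn1cc(C(=O)Nc2ccccc2)c(=O)c2cc(F)c(N3CCNC(C)C3)c(F)c21` gives 7400 nM. Compound 2 `CCn1cc(C(=O)Nc2ccc(C)c([N+](=O)[O-])c2)c(=O)c2cc(F)c(N3CCNC(C)C3)c(F)c21` gives 4200 nM, and compound 3 `CCn1cc(C(=O)Nc2ccc(OC)cc2)c(=O)c2cc(F)c(N3CCNC(C)C3)c(F)c21` gives 7300 nM. Compound 1 stands at the highest of the three numbers, but the step of a 1.0-fold lower number from compound 1 to compound 3 (0.01 log units; within the scatter) and the step of a 1.8-fold lower number from compound 1 to compound 2 (0.25 log units; within the scatter) both lie within the scatter, so the three cannot be ordered. Compound 4 `CCn1cc(C(=O)Nc2nccs2)c(=O)c2cc(F)c(N3CCNC(C)C3)c(F)c21` has not yet been measured; it differs from compound 1 by 1,3-thiazol-2-yl in place of phenyl on an amide-type nitrogen. For the measured compounds named here, the steps that bear on this change are the two in which the group on the amide-type nitrogen was altered, a 1.8-fold lower number from compound 1 to compound 2 (0.25 log units; within the scatter) and a 1.0-fold lower number from compound 1 to compound 3 (0.01 log units; within the scatter), neither beyond the scatter, together with a 1.7-fold higher number from compound 2 to compound 3 (0.24 log units; within the scatter), also within the scatter. No change of the group on the amide-type nitrogen has so far moved the number beyond the scatter. Compound 4 is therefore expected to stay close, the estimated step being a 1.1-fold lower number from compound 1 to compound 4 (0.02 log units; within the scatter). Compound 4 is expected to give 7000 nM in this assay, in a range from 3000 nM to 16000 nM.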

Compound 4, half-maximal inhibitory concentration: > 50000 nM
Compound 4 was reported as a limit; the forecaster's own chance of this, stated with the estimate: 10%; middle value at least 7.1-fold (0.85 log units) away from the limit.
By their numbers in this assay, from the lowest: compounds 2, 3 and 1 (each within the scatter of the next). At a limit, above all of these: compound 4.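

Compound 4 in this assay is reported as a limit, not a number: the limit of > 50000 nM in this assay, at which 1 of the 4 values shown sits.

Even so, its steps are readable: an at least 6.7-fold higher number from compound 1 to compound 4 (0.82 log units; beyond the scatter), an at least 6.8-fold higher number from compound 3 to compound 4 (0.83 log units; beyond the scatter) and an at least 11-fold higher number from compound 2 to compound 4 (1.07 log units; beyond the scatter). For the compounds shown here, the earlier exchanges among phenyl, 4-methoxyphenyl and 4-methyl-3-nitrophenyl all stayed within the scatter, so this is the first sign that the group on the amide-type nitrogen can move the number beyond it, and it comes with the change from a six-membered aromatic ring of carbon only to 1,3-thiazol-2-yl.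

The compounds shown do not separate the ring size from the ring nitrogen or the sulfur. Pyridin-2-yl or thiophen-2-yl on the same nitrogen would speak to that, and how either would read in this assay remains open.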